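The compounds below may be only part of what the source reports. "The series", "measured", "known", "first", "only" and "open" are said of these compounds alone.

Working notes on the series. In a functional assay on DLA cells (Mus musculus) for cytotoxicity, read by trypan blue exclusion, with a stated time of 48 h (on this read-out higher numbers stand for weaker inhibition and lower numbers for stronger inhibition), compound 1 `Cc1ccc(OCC(=O)NNC(=O)c2cc3ccccc3oc2=O)c(C(=O)c2ccccc2)c1` gives 89100 nM, and compound 2 `Cc1ccc(OCC(=O)NNC(=O)c2cc3ccccc3oc2=O)c(C(=O)c2ccc(Br)cc2)c1` gives 95500 nM; the two numbers sit within the scatter of each other, so compound 1 is not separated from compound 2 by any step that means anything. Among the compounds with values here, the one step measured so far, a 1.1-fold higher number from compound 1 to compound 2 (0.03 log units; within the scatter), adds a halogen to the benzoyl aryl and leaves the read-out where it was.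

Compound 3 `Cc1ccc(C(=O)c2cc(C)ccc2OCC(=O)NNC(=O)c2cc3ccccc3oc2=O)cc1` is the next case on the same aryl: methyl in place of hydrogen on an aromatic carbon. Within the data shown here, the only step that bears on it is a 1.1-fold higher number from compound 1 to compound 2 (0.03 log units; within the scatter), which changed the same ring in the same kind of way and stayed inside the scatter. On that basis compound 3 is expected to show no step beyond the scatter, the expected change being a 1.0-fold higher number from compound 1 to compound 3 (0.00 log units; within the scatter). For compound 3 the estimate in this assay is 90000 nM, with a range from 45000 nM to 180000 nM.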

Compound 3, half-maximal inhibitory concentration: 87300 nM
Compound 3: the middle estimate sits 1.0-fold (0.01 log units) above what was measured; the measured number falls inside the stated range.
By their numbers in this assay, from the lowest: compounds 3, 1 and 2 (each within the scatter of the next).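

In this assay, methyl at the carbon para to a large group on the benzoyl aryl stays within the scatter (a 1.0-fold lower number from compound 1 to compound 3 (0.01 log units; within the scatter)), so the flat result seen with bromo is not confined to a halogen. Exchanging the two substituents at this carbon also stays within the scatter (a 1.1-fold lower number from compound 2 to compound 3 (0.04 log units; within the scatter)), which leaves hydrogen, bromo and methyl here not told apart by this read-out. Nothing available bears on why this position gives so little change.

The compounds shown leave open whether a group of another kind at this carbon, such as an amine or a carboxylic acid, would move the number beyond the scatter. They also leave open whether a change elsewhere on the shared core, such as a longer chain, would do so.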